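Amide substituent variation on the shared core: compound 3

The source may hold more compounds than are shown below. What is called first, only, known or untested is meant among the compounds shown, and "the series" means these compounds.

compound 1 `O=C(C1CC1)N1CCc2nc(C#Cc3ccccc3)sc2C1` — 290 nM
compound 2 `O=C(C1CCCCO1)N1CCc2nc(C#Cc3ccccc3)sc2C1` — > 10000 nM

In an assay on HEK293 cells for negative allosteric modulation of metabotropic glutamate receptor 5 (Homo sapiens), read by FLIPR, with a stated time of 1 h (on this read-out lower numbers stand for stronger inhibition and higher numbers for weaker inhibition), compound 1 gives 290 nM. For compound 2 the reading of > 10000 nM is a limit of this assay and not a number; compound 2 thus sits at the limit of > 10000 nM in this assay, at which 1 of the 2 values shown sits. For the measured compounds named here, the single measured step, an at least 34-fold higher number from compound 1 to compound 2 (1.53 log units; beyond the scatter), is large and beyond the scatter, showing that the group on the carbonyl carbon can move the number far in this assay.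

Compound 3 `Cc1cccc(C(=O)N2CCc3nc(C#Cc4ccccc4)sc3C2)n1` carries 6-methylpyridin-2-yl in place of oxan-2-yl on a carbonyl carbon. Going by the values given here, no measured step covers this particular exchange; the only one on record touches the same place and starts from a limit, so the size of the coming step is uncertain. Compound 3 is expected to fall back into the measurable range, with an expected step of an at least 66-fold lower number from compound 2 to compound 3 (1.82 log units; beyond the scatter). Compound 3 is estimated at 150 nM, with a range from 20 nM to 3000 nM.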

Compound 3, half-maximal inhibitory concentration: > 10000 nM
Compound 3 ended at the assay's limit; the forecaster's own chance of this, stated with the estimate: 15%; middle value at least 66-fold (1.82 log units) away from the limit.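

Exchanging cyclopropyl for 6-methylpyridin-2-yl on the carbonyl carbon gives an at least 34-fold higher number from compound 1 to compound 3 (1.53 log units; beyond the scatter) in this assay, so the loss at this position is not confined to oxan-2-yl. A six-membered aromatic ring with 1 hetero atom here fares no better in this read-out than the non-aromatic one; the readings for compound 2 and compound 3 are both limits, so the step between them cannot be read. Among the three compounds, only compound 1 gives a measurable number, and the rest reach the same ceiling: the limit of > 10000 nM in this assay, at which 2 of the 3 values shown sit.

On these data alone, how far compound 2 and compound 3 lie beyond that limit remains open. Also open, as far as these compounds go, is whether cyclobutyl, isopropyl, phenyl or a dimethylamino group on the carbonyl carbon would stay in the measurable range, as cyclopropyl does.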